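This account rests on a few compounds, and the source may have more. Where it says the series, first, only, none or still open, it means among the compounds named here.

Among the measured compounds shown here, only two compounds have been measured so far, and they offer little to separate them. In a functional assay on A549 cells (Homo sapiens) for cytotoxicity (a lower number here means a stronger inhibitor, a higher number a weaker inhibitor), compound 1 `CC(=O)Oc1cc(C)c(OC(C)=O)c2c1CC=C(CCC=C(C)C)C2` gives 2900 nM and compound 2 `CC(C)=CCCC1=CCC2=C(C1)C(=O)C=CC2=O` gives 2100 nM. These two numbers lie within the scatter of each other, so compound 2 cannot be ranked against compound 1, and both sit at the same rough level of cytotoxicity.

The next compound to be tested is compound 3 `CC(C)=CCCC1=CCC2=C(C1)C(=O)C(C)=CC2=O`, which differs from compound 2 in a single place: methyl in place of hydrogen on a double-bonded ring carbon. In words, this is methyl in place of hydrogen on a double-bonded ring carbon.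

For the measured compounds named here, no pair of measured compounds shows what such a change does in this assay, so the expectation starts from compound 2 at 2100 nM. A single added carbon gives no firm reason to predict a direction, and a step beyond the scatter is not expected. The estimated step is small: a 1.2-fold lower number from compound 2 to compound 3 (0.07 log units; within the scatter). For compound 3 the expected value is 1800 nM, with an estimated range from 700 nM to 4500 nM.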

Compound 3, half-maximal inhibitory concentration: 3900 nM
Compound 3: middle estimate off by 2.2-fold (0.34 log units), on the low side; measured number inside the range.
By their numbers in this assay, from the lowest: compounds 2, 1 and 3 (each within the scatter of the next).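

In this assay, among the compounds shown here, methyl in place of hydrogen on a double-bonded ring carbon gives a 1.9-fold higher number from compound 2 to compound 3 (0.27 log units; within the scatter), the first reading of a change made in a single place in this set. It shows that this ring carbon can carry a methyl without a step that stands clear of the normal variation between repeated measurements, so hydrogen and methyl at this position cannot be told apart in this test, and a single pair gives no reliable direction for the change. No separate measurement bears on this result, so the data give no explanation for it.

The compounds shown leave open whether this position would respond to a group other than methyl, such as a longer chain like propyl, an amine or a carboxylic acid, any of which might produce a step beyond the scatter. They also leave open whether a methyl would give a similarly small step elsewhere on the shared core, or whether the same change would behave alike on a core carrying other groups.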